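The source may report more compounds than this note shows. Statements on the series, on what has been measured and on what is new or still open speak of the compounds shown alone.

Measured compounds:
Compound 1 `COC(=O)CC1CCN(C[C@H]2CN(c3ccc(-n4cc(-c5ccccn5)cn4)c(F)c3)C(=O)O2)CC1` — in an ADME assay on HEK293-A cells (Homo sapiens) for cytotoxicity, read by MTT assay, with a stated time of 48 h (a higher number here means a weaker inhibitor, a lower number a stronger inhibitor), compound 1 gives 224 ug/mL.
Compound 2 `O=C1O[C@@H](CN2CCC(O)CC2)CN1c1ccc(-n2cc(-c3ccccn3)cn2)c(F)c1` — in this assay compound 2 reaches only the assay's limit, > 400 ug/mL.
Compound 3 `O=C(OC[C@H]1CN(c2ccc(-n3cc(-c4ccccn4)cn3)c(F)c2)C(=O)O1)c1ccccc1` — in this assay compound 3 likewise reaches only the assay's limit, > 400 ug/mL.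

Compound 3 therefore stands at the upper edge of what has been measured, sharing the same limit with compound 2 (the limit of > 400 ug/mL in this assay, at which 2 of the 3 values shown sit). Compound 4 `COC[C@H]1CN(c2ccc(-n3cc(-c4ccccn4)cn3)c(F)c2)C(=O)O1` differs from compound 3 by methyl in place of benzoyl on an oxygen on a saturated carbon. For the measured compounds named here, no measured step makes this exact change; the nearest are an at least 1.7-fold higher number from compound 1 to compound 3 (0.25 log units; that floor lies within the scatter) and a step that the two limits leave unreadable from compound 2 to compound 3, both at the same position of the shared core, and neither reads as a change beyond the scatter. The step of a number no higher from compound 3 to compound 4 (the limit leaves the size open) is therefore expected to be small. Compound 4 is estimated at 400 ug/mL, between 200 ug/mL and 800 ug/mL, most likely again only a limit in this assay.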

Compound 4, half-maximal inhibitory concentration: > 400 ug/mL
Compound 4 ended at the assay's limit; the forecaster's own chance of this, stated with the estimate: 70%; the middle value lies on the limit itself.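

In this assay compound 4 gives > 400 ug/mL, a limit of the assay, so a group as small as methoxy on this saturated chain carbon reaches that limit with no ring in the group. Replacing 4-((methoxycarbonyl)methyl)piperidin-1-yl with methoxy gives an at least 1.7-fold higher number from compound 1 to compound 4 (0.25 log units; that floor lies within the scatter). The steps to compound 4 from compound 2 and from compound 3 cannot be read, because both ends of each are limits: the limit of > 400 ug/mL in this assay, at which 3 of the 4 values shown sit.

From the compounds shown here alone, how far beyond the limit these compounds lie stays open. So does whether a carboxylic acid or an open-chain amine such as dimethylamino here would give a measurable value, as compound 1 does.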